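The source may hold more compounds than are shown below. What is called first, only, known or untested is meant among the compounds shown, and "the series" means these compounds.

Working notes on the series.

Compound 3 `Cc1ccc2c(NCc3ccc(NC(=O)C4CCN(C)CC4)cc3)nc(N(C)C)nc2c1` carries a methyl group on the amine nitrogen in the ring. In a functional assay on SV5A8 cells (Homo sapiens) for cytotoxicity (on this read-out higher numbers stand for weaker inhibition and lower numbers for stronger inhibition), compound 3 gives only a limit, > 17300 nM. Compound 1 `Cc1ccc2c(NCc3ccc(NC(=O)C4CCN(Cc5ccco5)CC4)cc3)nc(N(C)C)nc2c1` has furan-2-yl at the same place; in this assay compound 1 also gives only a limit, > 20000 nM. Compound 2 `COc1ccc(CN2CCC(C(=O)Nc3ccc(CNc4nc(N(C)C)nc5cc(C)ccc45)cc3)CC2)cc1` has 4-methoxyphenyl there, and in this assay compound 2 gives only a limit as well, > 6180 nM. All three values are limits, so the steps a step that the two limits leave unreadable from compound 1 to compound 3, a step that the two limits leave unreadable from compound 2 to compound 3 and a step that the two limits leave unreadable from compound 1 to compound 2 cannot be read in size or direction; the limits (the limit of > 17300 nM in this assay, at which 1 of the 3 values shown sits), the limit of > 20000 nM in this assay, at which 1 of the 3 values shown sits, and the limit of > 6180 nM in this assay, at which 1 of the 3 values shown sits, only show that none of the three reaches a measurable number.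

Compound 4 `Cc1ccc2c(NCc3ccc(NC(=O)C4CCN(CC(C)C)CC4)cc3)nc(N(C)C)nc2c1` differs from compound 3 in that (isopropyl in place of hydrogen on a saturated chain carbon bound to an amine nitrogen in a ring). The measured steps at this place are all unreadable, so no direction can be drawn from them; a limit is again the likelier outcome. Compound 4 is therefore expected near 20000 nM, between 8000 nM and 50000 nM, so that the expected step that the limit leaves unreadable from compound 3 to compound 4 stays within the scatter.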

Compound 4, half-maximal inhibitory concentration: > 10500 nM
Compound 4: a limit, no number (the forecaster's own chance of this, stated with the estimate: 85%); the middle value lies beyond the limit too.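

Compound 4 again gives only a limit in this assay, > 10500 nM, so its steps from compound 1, compound 2 and compound 3 cannot be read in size or direction. The compounds shown leave open whether the group at this place changes this read-out at all, since all four values are limits.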